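This account rests on a few compounds, and the source may have more. Where it says the series, first, only, none or still open, it means among the compounds named here.

Measured so far:
- compound 1, `Fc1ccc(Cc2nn3c(-c4cccnc4)nnc3s2)cc1`: 1650 nM
- compound 2, `c1cncc(-c2nnc3sc(-c4ccc[nH]4)nn23)c1`: 5140 nM
- compound 3, `Oc1ccccc1OCc1nn2c(-c3cccnc3)nnc2s1`: 3670 nM

In a functional assay on NCI-H157 cells (Homo sapiens) for cytotoxicity, read by sulforhodamine B assay (on this read-out lower numbers stand for stronger inhibition and higher numbers for weaker inhibition), compound 3 gives 3670 nM, the second highest of the three numbers. Its nearest neighbour is compound 2, which in this assay gives 5140 nM, a gap that lies within the usual scatter, so the two cannot be told apart. Its furthest neighbour is compound 1, which gives 1650 nM, a lower number by a margin beyond the scatter.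

Compound 4, `Cc1ccc(OCc2nn3c(-c4cccnc4)nnc3s2)cc1`, has not yet been measured in this assay. It differs from compound 3 in one place: 4-methylphenyl in place of 2-hydroxyphenyl on an oxygen on a saturated carbon. Among the compounds with values here, no step between two measured compounds matches this change, so nothing in the present set shows how this assay responds to it. The three measured numbers all sit within a narrow band, and compound 3 itself lies in the middle of that band, so the expected step from compound 3 to compound 4 is a 1.2-fold lower number from compound 3 to compound 4 (0.09 log units; within the scatter), which is taken to be no step beyond the scatter in either direction. On that basis compound 4 is estimated to give 3000 nM in this assay, with a range from 1200 nM to 8000 nM.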

Compound 4, half-maximal inhibitory concentration: 2980 nM
Compound 4: middle estimate off by 1.0-fold (0.00 log units), on the high side; measured number inside the range.
By their numbers in this assay, from the lowest: compounds 1, 4, 3 and 2 (each within the scatter of the next, the first and the last beyond it).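

In this assay the first step read at this position, on an oxygen on a saturated carbon (a 1.2-fold lower number from compound 3 to compound 4 (0.09 log units; within the scatter)), stays within the scatter. Here 4-methylphenyl, with 0 hydrogen-bond donors and 0 hydrogen-bond acceptors, cannot be told apart from 2-hydroxyphenyl, with 1 of each, so this one exchange gives no sign that the hydrogen-bond donor and acceptor counts of this group matter to the read-out. No further measurement bears on why the two compounds cannot be told apart.

The step alters the substituent and its numbered place on the aromatic ring together, so the compounds shown do not separate the two, and 2-methylphenyl or 4-hydroxyphenyl at the same position would be needed to do that. They also leave open whether this position would still show no step beyond the scatter with an amine or a carboxylic acid on that ring, or with a longer chain carrying the oxygen.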